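Fluorophenyl variants on the shared core: the fluorine position

The compounds below may be only part of what the source reports. "The series", "measured", "known", "first", "only" and "open" are said of these compounds alone.

Measured so far:
Compound 1 `CCCCCCOc1ccc2c(c1)C(=O)NCCO2` gives 47.3 mg/kg in a functional assay on the whole organism with Mus musculus as the target, in the maximal electroshock model, with stated times of 30 min and 4 h; on this read-out higher numbers stand for an effect only at larger amounts of compound and lower numbers for an effect already at smaller amounts.
Compound 2 `O=C1NCCOc2ccc(OCc3cccc(F)c3)cc21` gives 73.1 mg/kg in this assay.

Compound 2 carries the highest of the two numbers, but its nearest neighbour compound 1 lies within the scatter of it, so no order between the two is established. Going by the values given here, the step of a 1.5-fold higher number from compound 1 to compound 2 (0.19 log units; within the scatter) is the only measured comparison and it stays within the scatter.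

Compound 3 `O=C1NCCOc2ccc(OCc3ccccc3F)cc21` is not yet measured. It differs from compound 2 in one place: 2-fluorophenyl in place of 3-fluorophenyl on a saturated chain carbon bound to an oxygen on an aromatic ring. Among the compounds with values here, no measured step bears directly on moving the fluorine within the fluorophenyl group; the only related step, from compound 1 to compound 2, exchanged the whole group and was itself within the scatter. With nothing in the data pointing to either direction, compound 3 is expected to give 70 mg/kg in this assay, with a range of 35 mg/kg to 140 mg/kg. The expected step of a 1.0-fold lower number from compound 2 to compound 3 (0.02 log units; within the scatter) is therefore estimated to lie within the scatter.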

Compound 3, dose for half-maximal effect: 45.6 mg/kg
Compound 3: the middle estimate sits 1.5-fold (0.19 log units) above what was measured; the measured number falls inside the stated range.
By their numbers in this assay, from the lowest: compounds 3, 1 and 2 (each within the scatter of the next).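

Moving the fluorine at this place, on a saturated chain carbon bound to an oxygen on an aromatic ring, gives in this assay a 1.6-fold lower number from compound 2 to compound 3 (0.20 log units; within the scatter); this change therefore sets no order between the two fluorophenyl compounds. Exchanging pentyl for 2-fluorophenyl at the same place gives a 1.0-fold lower number from compound 1 to compound 3 (0.02 log units; within the scatter), so neither fluorophenyl group is separated from the pentyl chain, and the three compounds remain within the scatter of one another. Nothing available on these compounds bears on this result.

As far as these compounds go, it remains open whether another group at this place, such as a phenyl ring without fluorine, an amine or a longer chain, would shift the number beyond the scatter. From the compounds shown here alone, it is equally open whether replacing the amide hydrogen of the shared core would do so.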